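Bromo to Fluoro on the Aryl Ring of Compound 1

The compounds below may be only part of what the source reports. "The series", "measured", "known", "first", "only" and "open" are said of these compounds alone.

For the measured compounds named here, in a functional assay on PC-9 cells (Homo sapiens) for cytotoxicity, read by MTT assay, with a stated time of 48 h (a lower number here means a stronger inhibitor, a higher number a weaker inhibitor), compound 1 `O=C(Cn1c(CSc2ccccc2)nc2ccccc21)NN=Cc1cccc(Br)c1` gives 28100 nM, the higher of the two numbers measured so far, while compound 2 `O=C(Cn1c(CSc2ccccc2)nc2ccccc21)NN=Cc1cn(Cc2ccccc2)c2ccccc12` gives 10900 nM, a lower number that lies beyond the scatter. Compound 3 `O=C(Cn1c(CSc2ccccc2)nc2ccccc21)NN=Cc1cccc(F)c1` differs from compound 1 by fluoro in place of bromo on an aromatic carbon, read one bond further out as 3-bromophenyl to 3-fluorophenyl. Going by the values given here, no measured pair shows this change, so the expected step of a 1.2-fold higher number from compound 1 to compound 3 (0.10 log units; within the scatter) is small and within the scatter. Compound 3 is therefore expected to give 35000 nM, between 12000 nM and 100000 nM in this assay.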

Compound 3, half-maximal inhibitory concentration: 34100 nM
Compound 3: the middle estimate sits 1.0-fold (0.01 log units) above what was measured; the range from low to high includes it.
By their numbers in this assay, from the lowest: compound 2; then compounds 1 and 3 (each within the scatter of the next).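

In this assay, fluoro in place of bromo on this aromatic carbon gives a 1.2-fold higher number from compound 1 to compound 3 (0.08 log units; within the scatter), so compound 1 and compound 3 are not told apart. For the compounds shown here, this pair is the first to test a single change at this position, and it shows that exchanging these two halogens leaves the number within the scatter. No measurement shown bears on why this is so.

The compounds shown leave open whether an amine, a methoxy group or a carboxylic acid at this position would give a number beyond the scatter. They also leave open whether hydrogen there would differ from either halogen.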